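The compounds below may be only part of what the source reports. "The series", "measured", "known", "first", "only" and "open" are said of these compounds alone.

Measured so far in a physicochemical assay for lipophilicity; on this read-out higher numbers stand for higher lipophilicity and lower numbers for lower lipophilicity:
- Compound 1 `CC#CCn1c(N2CCC[C@@H](N)C2)cc(=O)n(Cc2ccc(OC)c(OC)c2)c1=O`: 1.55
- Compound 2 `CC#CCn1c(N2CCC[C@@H](N)C2)cc(=O)n(Cc2cc(Br)c(OC)c(OC)c2)c1=O`: 2.38

Of these two, compound 1 has the lower number in this assay, and compound 2 sits above it. Among the measured compounds shown here, the one measured step is a number 0.83 log units higher from compound 1 to compound 2 (beyond the scatter), with bromo in place of hydrogen on an aromatic carbon.

Compound 3 `CC#CCn1c(N2CCC[C@@H](N)C2)cc(=O)n(Cc2cc(C)cc(C)c2)c1=O` has not yet been measured. Its difference from compound 1 is 3,5-dimethylphenyl in place of 3,4-dimethoxyphenyl on a saturated chain carbon bound to an aromatic nitrogen, with 3,5-dimethylphenyl in place of 3,4-dimethoxyphenyl on a saturated chain carbon bound to an aromatic nitrogen. For the measured compounds named here, no measured compound carries this group, so the evidence is thin. The bromo step is a different change, and it bears on this one only as a guide to size. Going by that step of a number 0.83 log units higher from compound 1 to compound 2 (beyond the scatter), a rise of similar or slightly larger size is expected in this assay, beyond the scatter. The estimated step is a number 0.95 log units higher from compound 1 to compound 3 (beyond the scatter). For compound 3 the expected value is 2.5, with an estimated range from 2 to 3.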

Compound 3, partition coefficient: 2.78
For compound 3 the middle estimate is 0.28 log units below the measured one, within the range that was stated.
By their numbers in this assay, from the lowest: compound 1; then compound 2; then compound 3.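

In this assay, 3,5-dimethylphenyl in place of 3,4-dimethoxyphenyl on a saturated chain carbon bound to an aromatic nitrogen gives a number 1.23 log units higher from compound 1 to compound 3 (beyond the scatter). The earlier step changed a single hydrogen on a ring that kept both methoxy groups, whereas this one shows that the number also moves when the whole aryl group is exchanged, with the group going from 10 heavy atoms to 8 and from 2 hydrogen-bond acceptors to 0, so in this pair the smaller group carries the higher number. No supporting evidence explains this shift or separates the departure of the methoxy groups from the arrival of the methyl groups.

The compounds shown leave open how much of the step would remain with only one methyl group on the ring, and whether the bromo step would carry over to the 3,5-dimethylphenyl group. They also leave open how this read-out would respond to a carboxylic acid or an amine on the ring in place of these groups.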